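A few compounds are considered here, and "the series" means these few. Any claim that something is new, unique, unknown or untested is made for them only; others in the source may bear on it.

Measured compounds in a functional assay on PANC-1 cells (Homo sapiens) for inhibition, read by MTT assay, with a stated time of 24 h, tested at 10 uM; on this read-out higher numbers stand for more inhibition at the one concentration tested (going by the name of the read-out) and lower numbers for less inhibition:

compound 1 `COc1ccc(NC(=O)Oc2cc(=O)n(CCCO)c3c2CC(CC=C(C)C)C(C)(C)C3)cc1`: 3.7%
compound 2 `COc1cccc(NC(=O)Oc2cc(=O)n(CCCO)c3c2CC(CC=C(C)C)C(C)(C)C3)c1`: 16.2%
compound 3 `CC(C)=CCC1Cc2c(OC(=O)Nc3ccc(F)cc3F)cc(=O)n(CCCO)c2CC1(C)C`: 69.7%

Compound 3 gives the highest number of the three in this assay, and both steps that lead to it are beyond the scatter: a number 66 percentage points higher from compound 1 to compound 3 (beyond the scatter) and a number 53.5 percentage points higher from compound 2 to compound 3 (beyond the scatter). The smaller step between the two methoxyphenyl compounds, a number 12.5 percentage points higher from compound 1 to compound 2 (beyond the scatter), is modest by comparison.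

Compound 4 `CC(C)=CCC1Cc2c(OC(=O)Nc3cccc(C(F)(F)F)c3)cc(=O)n(CCCO)c2CC1(C)C` differs from compound 3 in one place: 3-(trifluoromethyl)phenyl in place of 2,4-difluorophenyl on an amide-type nitrogen. Among the measured compounds shown here, no measured step covers this exact exchange. The two large steps toward compound 3 each swapped a methoxyphenyl for a fluorine-bearing aryl, and compound 4 keeps fluorine on its aryl, so a drop as large as those steps is not expected, yet nothing shown fixes the size of the change. Compound 4 is therefore expected to stay nearer compound 3 than compounds 1 or 2, with an expected step of a number 14.7 percentage points lower from compound 3 to compound 4 (beyond the scatter). The estimate for compound 4 in this assay is 55%, in the range 30% to 80%.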

Compound 4, a percentage reported as inhibition, at one concentration (the size of the read-out at that concentration, not a potency): 54.3%
The estimate for compound 4 lay 0.7 percentage points above the measured number; the range from low to high includes it.
By their numbers in this assay, from the lowest: compound 1; then compound 2; then compound 4; then compound 3.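

In this assay, the group on the amide-type nitrogen can change from 2,4-difluorophenyl to 3-(trifluoromethyl)phenyl with only a modest loss, a number 15.4 percentage points lower from compound 3 to compound 4 (beyond the scatter). The clearest new comparison is the exchange of trifluoromethyl for methoxy on an aromatic carbon, which gives a number 38.1 percentage points higher from compound 2 to compound 4 (beyond the scatter), while the exchange against 4-methoxyphenyl gives a number 50.6 percentage points higher from compound 1 to compound 4 (beyond the scatter). Across these four compounds, both fluorine-bearing aryl groups therefore give higher numbers than both methoxyphenyl groups, with no compound going against that pattern.

The compounds shown leave open whether a nitrile, a chlorine or a carboxylic acid on the aryl ring would fit this pattern, or whether an open alkyl chain could replace the ring. No measurement shown explains the differences among these groups.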